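The source may hold more compounds than are shown below. What is called first, only, known or untested is meant among the compounds shown, and "the series" means these compounds.

Compound 1 `CC#CC(CC(=O)O)c1ccc(OCc2ccc3nc(-c4ccc(C)cc4C)cn3c2)cc1`: in an assay on isolated protein for agonist activity at Free fatty acid receptor 1 (Homo sapiens) (on this read-out lower numbers stand for an effect already at smaller amounts and higher numbers for an effect only at larger amounts of compound), compound 1 gives 316 nM.
Compound 2 `CC#CC(CC(=O)O)c1ccc(OCc2ccn3cc(-c4ccc(C(C)C)cc4)nc3c2)cc1`: in this assay compound 2 gives 615 nM.
Compound 3 `CC#CC(CC(=O)O)c1ccc(OCc2ccc3nc(-c4cccc(C)c4)cn3c2)cc1`: in this assay compound 3 gives 1050 nM.

Compound 2 stands second highest of the three numbers. Its nearest neighbour is compound 3, and the gap between the two lies within the scatter; compound 1 is furthest away, and that gap too lies within the scatter. Compound 4 `CC#CC(CC(=O)O)c1ccc(OCc2ccn3cc(-c4ccc(C(F)(F)F)cc4)nc3c2)cc1` has not yet been measured. It differs from compound 2 in one place: trifluoromethyl in place of isopropyl on an aromatic carbon. Among the compounds with values here, the only step measured between compounds that differ in one place is a 3.3-fold higher number from compound 1 to compound 3 (0.52 log units; beyond the scatter), which alters the methyl pattern on the six-membered aromatic ring of carbon only at the end of the shared core. Within the data shown here, no measured step exchanges the group on that ring for one of a different kind, so nothing bears directly on the present change. That one step was modest; a step of similar size or smaller is expected from compound 2 to compound 4, a 1.1-fold lower number from compound 2 to compound 4 (0.05 log units; within the scatter), with no confident direction. Compound 4 is therefore estimated at 550 nM in this assay, within a range from 180 nM to 1700 nM.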

Compound 4, half-maximal effective concentration: 674 nM
For compound 4 the middle estimate is 1.2-fold (0.09 log units) below the measured one; the range from low to high includes it.
By their numbers in this assay, from the lowest: compounds 1, 2, 4 and 3 (each within the scatter of the next, the first and the last beyond it).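

In this assay, trifluoromethyl in place of isopropyl on the aromatic carbon para to a large group gives a 1.1-fold higher number from compound 2 to compound 4 (0.04 log units; within the scatter). Unlike the earlier step, which only altered a methyl pattern, this one exchanges the group on that ring for one of a different kind, and the two compounds cannot be told apart within the scatter. So at this place, in this core, a group of three carbons and a group of one carbon and three fluorines read alike, and nothing at hand accounts for this.

From the compounds shown here alone, it stays open whether a group of another kind at this place, such as an amine, a methoxy group or a carboxylic acid, would read alike too. Going by these compounds, it also stays open whether the same exchange would read alike on the core of compound 1.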